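The compounds below may be only part of what the source reports. "The series", "measured", "known", "first", "only" and "open" are said of these compounds alone.

Measured so far in a functional assay on MT4 cells (Homo sapiens), read by MTT assay (a lower number here means that less compound is tolerated, a higher number that more compound is tolerated), both entries being limits of the assay and not numbers:

- Compound 1 `C#C[C@]1(CO)OC(N2C=C(C)C(O)NC2=O)[C@@H](O)[C@@H]1O` gives > 350000 nM
- Compound 2 `C#C[C@]1(CO)O[C@@H](n2cc(C)c(=O)[nH]c2=O)C[C@@H]1O` gives > 380000 nM

Compound 2 stands at > 380000 nM, and this is a limit, so it has no exact place on the scale. Compound 1 likewise gives only a limit, > 350000 nM. Among the measured compounds shown here, no step between measured compounds is available, so the data do not show how a change at any single place moves this assay.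

Compound 3 `C#C[C@]1(CO)O[C@@H](n2cc(F)c(=O)[nH]c2=O)C[C@@H]1O` keeps the rest of compound 2 and carries fluoro in place of methyl on an aromatic carbon. For the measured compounds named here, with no measured precedent for this swap, the size of the change is uncertain. A moderate to large move toward less compound being tolerated is expected, though a result that again reaches only a limit would not be surprising.

The estimated change is an at least 6.3-fold lower number from compound 2 to compound 3 (0.80 log units; beyond the scatter). For compound 3 the expected value is 60000 nM, with an estimated range from 2000 nM to 400000 nM.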

Compound 3, half-maximal cytotoxic concentration: 3400 nM
Compound 3: the middle estimate sits 18-fold (1.25 log units) above what was measured; the range from low to high includes it.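

Of the three compounds shown, only compound 3 gives a number and not a limit in this assay (3400 nM). This shows that the aromatic carbon carrying the methyl of compound 2 is not indifferent in this assay: exchanging that one heavy atom for fluoro gives an at least 110-fold lower number from compound 2 to compound 3 (2.04 log units; beyond the scatter), toward less compound being tolerated. The true size of the step stays unknown, and the printed size is only its smallest possible value, since compound 2 gives a limit and not a number: the limit of > 380000 nM in this assay, at which 1 of the 3 values shown sits.

The compounds shown leave open whether the drop comes from fluoro itself or simply from the loss of methyl, and a chloro group or a plain hydrogen on the same aromatic carbon would separate these two readings. Going by these compounds, it also remains open whether the same exchange would act in the same way on the core of compound 1, which differs from compound 2 in more than one place and gives only a limit.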